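Moving a Hydroxyl Across a Shared Core

This account rests on a few compounds, and the source may have more. Where it says the series, first, only, none or still open, it means among the compounds named here.

Compound 1 `Oc1cccc(-c2cc(-c3ccsc3)cc(-c3cccc(O)c3)n2)c1`: 1310 nM
Compound 2 `Oc1ccc(-c2cc(-c3ccsc3)cc(-c3cccc(O)c3)n2)cc1`: 2230 nM
Compound 3 `Oc1cccc(-c2cc(-c3ccccn3)cc(-c3cccc(O)c3)n2)c1`: 3610 nM

All three were tested in a functional assay on DU-145 cells (Homo sapiens) for cytotoxicity, read by CCK-8 assay; on this read-out higher numbers stand for weaker inhibition and lower numbers for stronger inhibition. They share one core and differ only in the arms on it. Compound 3 differs from compound 1 by pyridin-2-yl in place of thiophen-3-yl on an aromatic carbon, and this gave a 2.8-fold higher number from compound 1 to compound 3 (0.44 log units; beyond the scatter). Compound 2 differs from compound 1 by 4-hydroxyphenyl in place of 3-hydroxyphenyl on an aromatic carbon, which gave a 1.7-fold higher number from compound 1 to compound 2 (0.23 log units; within the scatter). Compound 2 and compound 3 lie within the scatter of each other.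

Compound 4 `Oc1ccc(-c2cc(-c3ccccn3)cc(-c3cccc(O)c3)n2)cc1` has not yet been measured. It differs from compound 3 by 4-hydroxyphenyl in place of 3-hydroxyphenyl on an aromatic carbon. This is the same kind of change as that from compound 1 to compound 2, but not the same: the place is meta to a thiophen-3-yl group in the first pair and meta to a pyridin-2-yl group in the second. The expectation rests on the step of a 1.7-fold higher number from compound 1 to compound 2 (0.23 log units; within the scatter), taken as a guide. Compound 4 is therefore expected to give a 1.5-fold higher number from compound 3 to compound 4 (0.18 log units; within the scatter). For compound 4 the estimate in this assay is 5500 nM, expected to fall between 2500 nM and 12000 nM.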

Compound 4, half-maximal inhibitory concentration: 1980 nM
The estimate for compound 4 lay 2.8-fold (0.44 log units) above the measured number, and the stated range ends above it.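

In this assay, 4-hydroxyphenyl in place of 3-hydroxyphenyl gave a 1.8-fold lower number from compound 3 to compound 4 (0.26 log units; within the scatter), so this change did not keep one size from the core of compound 1 to the core of compound 3: the same change on two cores in this assay, a 1.7-fold higher number (0.23 log units; within the scatter) from compound 1 to compound 2 and a 1.8-fold lower number (0.26 log units; within the scatter) from compound 3 to compound 4, 3.1-fold (0.49 log units) apart, beyond the scatter of two such steps. Pyridin-2-yl in place of thiophen-3-yl gave a 1.1-fold lower number from compound 2 to compound 4 (0.05 log units; within the scatter), and it too failed to keep one size between the two cores: the same change on two cores in this assay, a 2.8-fold higher number (0.44 log units; beyond the scatter) from compound 1 to compound 3 and a 1.1-fold lower number (0.05 log units; within the scatter) from compound 2 to compound 4, 3.1-fold (0.49 log units) apart, beyond the scatter of two such steps. Both gaps rest on the same four compounds, so they form a single observation that the two changes do not add up independently here; they do not show why, nor whether this would hold on any other core.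

The compounds shown leave open whether a methoxy group or an amine in place of the hydroxyl would follow the same course. From the compounds shown here alone, it also remains open how a third arm, such as furan-2-yl, would behave in place of thiophen-3-yl or pyridin-2-yl.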